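Swapping the aryl group on two inactive analogues

The source may hold more compounds than are shown below. What is called first, only, known or untested is meant among the compounds shown, and "the series" means these compounds.

Measured compounds:
compound 1, `N#CC1=C(N)Oc2c(c3nc4ccccc4nc3c3ccccc23)C12C(=O)N(Cc1cnnn1-c1cccc(Cl)c1)c1ccccc12`: > 50000 nM
compound 2, `COc1ccc(-n2nncc2CN2C(=O)C3(C(C#N)=C(N)Oc4c(N)cc5nc6ccccc6nc5c43)c3ccccc32)cc1`: > 50000 nM

Two compounds were tested in an ADME assay on HUVEC cells (Homo sapiens) for antiproliferative activity, read by MTT assay, with a stated time of 48 h; on this read-out lower numbers stand for stronger inhibition and higher numbers for weaker inhibition. Compound 1 `N#CC1=C(N)Oc2c(c3nc4ccccc4nc3c3ccccc23)C12C(=O)N(Cc1cnnn1-c1cccc(Cl)c1)c1ccccc12` gave only a limit of the assay, > 50000 nM. Compound 2 `COc1ccc(-n2nncc2CN2C(=O)C3(C(C#N)=C(N)Oc4c(N)cc5nc6ccccc6nc5c43)c3ccccc32)cc1` likewise gave only a limit, > 50000 nM. On the numbers shown, compound 2 therefore stands at the limit of this assay, and both values sit there (the limit of > 50000 nM in this assay, at which 2 of the 2 values shown sit), so neither compound shows measurable inhibition of the cells.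

Compound 3 `Cc1cc(C)c(-n2nncc2CN2C(=O)C3(C(C#N)=C(N)Oc4c(N)cc5nc6ccccc6nc5c43)c3ccccc32)c(C)c1` differs from compound 2 in one place (2,4,6-trimethylphenyl in place of 4-methoxyphenyl on an aromatic nitrogen). Within the data shown here, no step between measured compounds is available, so no measured change of this kind can guide the size of the effect. With compound 2 already at the limit, the expected step is a number no higher from compound 2 to compound 3 (the limit leaves the size open), that is, none beyond the usual scatter. Compound 3 is estimated at 50000 nM, within 15000 nM to 150000 nM, and is expected most probably to be reported again only as a limit.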

Compound 3, half-maximal inhibitory concentration: > 50000 nM
Compound 3 was reported as a limit; the forecaster's own chance of this, stated with the estimate: 80%; the middle value lies on the limit itself.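

Among these compounds, compound 2 and compound 3 both stand only at a limit of the assay, so no step between them can be read: the limit of > 50000 nM in this assay, at which 3 of the 3 values shown sit. The compounds shown leave open whether 4-methoxyphenyl and 2,4,6-trimethylphenyl differ at all in their effect on these cells, and whether any analogue with this shared core gives a measurable value.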